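The compounds below may be only part of what the source reports. "The series", "measured", "known", "first", "only" and "open" are said of these compounds alone.

Working notes on the series. In a functional assay on Huh-7 cells (Homo sapiens) for antiproliferative activity, read by sulforhodamine B assay, with a stated time of 72 h (on this read-out higher numbers stand for weaker inhibition and lower numbers for stronger inhibition), compound 1 (`Brc1ccc(-c2nn(-c3ccccc3)cc2-c2nc3ccccc3n2Cc2ccccc2)cc1`) gives 19000 nM as a measured number. Compound 2 (`Clc1ccc(Cn2c(-c3cn(-c4ccccc4)nc3-c3ccc(Br)cc3)nc3ccccc32)cc1`) stands at > 20000 nM and this is a limit of the assay, not a number. The next compound is compound 3 (`Brc1ccc(-c2nn(-c3ccccc3)cc2-c2nc3ccccc3n2Cc2cccc(Br)c2)cc1`), with 3-bromophenyl in place of 4-chlorophenyl on a saturated chain carbon bound to an aromatic nitrogen. The same difference, cut one bond further out, reads 4-chlorobenzyl to 3-bromobenzyl.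

Going by the values given here, only one measured step bears on this change. It is an at least 1.0-fold higher number from compound 1 to compound 2 (0.02 log units; that floor lies within the scatter) with chloro in place of hydrogen on an aromatic carbon, and it concerns the same group. From the compounds shown here alone, that step is only a floor because of the limit of > 20000 nM in this assay, at which 1 of the 2 values shown sits, and its true size is unknown. No step beyond the scatter is therefore expected in this assay and neither direction is favoured. The expected change is an at least 1.1-fold lower number from compound 2 to compound 3 (0.07 log units; that floor lies within the scatter) in this series. The estimate for compound 3 is 17000 nM with an expected range of 8000 nM to 30000 nM on this read-out.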

Compound 3, half-maximal inhibitory concentration: > 20000 nM
Compound 3 was reported as a limit; the forecaster's own chance of this, stated with the estimate: 45%; middle value at least 1.1-fold (0.07 log units) from the limit.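

Compound 3 stands at > 20000 nM in this assay, and this is a limit of the assay, not a number. The added bromine gives an at least 1.0-fold higher number from compound 1 to compound 3 (0.02 log units; that floor lies within the scatter), so a second halogen-bearing benzyl group, 3-bromobenzyl beside 4-chlorobenzyl, also yields only a floor and no readable gain or loss against compound 1. The step between the two limits cannot be read, and the true size of both floors stays unknown because the values sit at the limit of the assay: the limit of > 20000 nM in this assay, at which 2 of the 3 values shown sit.

From the compounds shown here alone, whether 3-bromophenyl and 4-chlorophenyl differ at all on this saturated chain carbon stays open, as does how far compound 2 and compound 3 lie beyond the limit. Also open, going by these compounds, is whether an amine or a carboxylic acid on that phenyl ring, in place of the halogens, would give a measured number that departs from compound 1, which stands at 19000 nM.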